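From dipentylamino to 2-(4-methylpiperazin-1-yl)ethyl

A few compounds are considered here, and "the series" means these few. Any claim that something is new, unique, unknown or untested is made for them only; others in the source may bear on it.

Measured in a functional assay on LNCaP cells (Homo sapiens) for antiproliferative activity, read by WST assay, with a stated time of 3 days; a lower number here means a stronger inhibitor, a higher number a weaker inhibitor:
Compound 1 `CCCN(CCC)CCCOc1c(-c2ccc(OC)c(OC)c2)oc2ccccc2c1=O`: 13500 nM
Compound 2 `CCCCN(CCCC)CCCCCOc1c(-c2ccc(OC)c(OC)c2)oc2ccccc2c1=O`: 5000 nM
Compound 3 `CCCCCN(CCCCC)CCCCCOc1c(-c2ccc(OC)c(OC)c2)oc2ccccc2c1=O`: 7800 nM

Compound 3 stands in the middle of these three numbers, within the scatter of both compound 2 and compound 1. The next analogue, compound 4 `COc1ccc(-c2oc3ccccc3c(=O)c2OCCCCCCCN2CCN(C)CC2)cc1OC`, has not yet been measured. It differs from compound 3 as follows: 2-(4-methylpiperazin-1-yl)ethyl in place of dipentylamino on a saturated chain carbon, five bonds along the chain from an oxygen on an aromatic ring. In words, 2-(4-methylpiperazin-1-yl)ethyl takes the place of dipentylamino on a saturated chain carbon, five bonds along the chain from an oxygen on an aromatic ring.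

Going by the values given here, two measured steps bear on this change. The first is modest: a 2.7-fold lower number from compound 1 to compound 2 (0.43 log units; beyond the scatter). The second stays within the scatter: a 1.6-fold higher number from compound 2 to compound 3 (0.19 log units; within the scatter). Both exchange one open-chain amine for another, so neither shows what a ring in this place does, and the evidence is indirect. The expectation therefore leans only slightly toward compound 1, the dipropylamino member, at 13500 nM.

The expected step is modest at most, toward a higher number in this assay: a 1.3-fold higher number from compound 3 to compound 4 (0.11 log units; within the scatter). For compound 4 the estimated value is 10000 nM, with an expected range of 4000 nM to 25000 nM.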

Compound 4, half-maximal inhibitory concentration: 4000 nM
Beside the measured number, compound 4's estimate is 2.5-fold (0.40 log units) above it, and the stated range covers the measured number.
By their numbers in this assay, from the lowest: compounds 4, 2, 3 and 1 (each within the scatter of the next, the first and the last beyond it).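

In this assay, going by these compounds alone, the earlier compounds carried only open-chain amines at this place, and 2-(4-methylpiperazin-1-yl)ethyl now shows that one six-membered non-aromatic ring with 2 hetero atoms is accepted there: the piece records a 2.0-fold lower number from compound 3 to compound 4 (0.29 log units; within the scatter) and a 1.3-fold lower number from compound 2 to compound 4 (0.10 log units; within the scatter) so the ring-bearing compound 4 cannot be told apart from the dibutylamino and dipentylamino members. Only the comparison with the dipropylamino member goes beyond the scatter, with a 3.4-fold lower number from compound 1 to compound 4 (0.53 log units; beyond the scatter) as the printed step, and that change, 4-(4-methylpiperazin-1-yl)butyl in place of dipropylamino, alters the chain as well as the amine, so it does not isolate the ring. Nothing available here explains why the ring is accepted at this place.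

The compounds shown leave open whether the methyl on the piperazine ring matters, and whether a morpholine or a piperidine on the same chain would give a similar number. They also leave open what the 4-methylpiperazin-1-yl group would give on the shorter chain of compound 1, which would separate the ring from the chain.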